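A few compounds are considered here, and "the series" means these few. Any claim that something is new, unique, unknown or untested is made for them only; others in the source may bear on it.

Compound 1 `CN1CCN(CCCCCn2c3c(c4ccccc42)C(=O)c2c[n+]([O-])c4ccccc4c2C3=O)CC1`: 2270 nM
Compound 2 `CC1(C)OCC(Cn2cc(Cn3c4c(c5ccccc53)C(=O)c3c[n+]([O-])c5ccccc5c3C4=O)nn2)O1`: 230 nM
Compound 3 `CC1(C)OC[C@H](Cn2cc(Cn3c4c(c5ccccc53)C(=O)c3c[n+]([O-])c5ccccc5c3C4=O)nn2)O1`: 530 nM

Of the compounds shown here, three sharing one core have been measured in a functional assay on MDA-MB-231 cells (Homo sapiens) for cytotoxicity, read by MTT assay, with a stated time of 72 h; on this read-out lower numbers stand for stronger inhibition and higher numbers for weaker inhibition. Compound 1 stands highest of the three numbers there; compound 3 comes nearest to it, and compound 2 lies furthest from it. For the measured compounds named here, the only step between measured compounds that differ in one place runs from compound 2 to compound 3: a 2.3-fold higher number from compound 2 to compound 3 (0.36 log units; beyond the scatter). That step rests on (the fact that one of compounds 2 and 3 is drawn with a defined configuration and the other without, at the place where they differ), and it touches neither the chain nor the piperazine of compound 1, so it does not bear on the change followed here.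

Compound 4 `CCCN1CCN(CCCCn2c3c(c4ccccc42)C(=O)c2c[n+]([O-])c4ccccc4c2C3=O)CC1` has not yet been measured. It differs from compound 1 in this way: 4-propylpiperazin-1-yl in place of (4-methylpiperazin-1-yl)methyl on a saturated chain carbon, four bonds along the chain from an aromatic nitrogen. Going by the values given here, no measured step covers a change of this kind, so there is no basis for expecting a shift beyond the scatter in this assay, in either direction. The step from compound 1 to compound 4 is therefore expected to be small: a 1.1-fold lower number from compound 1 to compound 4 (0.05 log units; within the scatter). Compound 4 is estimated at 2000 nM, within a range from 700 nM to 6000 nM.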

Compound 4, half-maximal inhibitory concentration: 2980 nM
Beside the measured number, compound 4's estimate is 1.5-fold (0.17 log units) below it; measured number inside the range.
By their numbers in this assay, from the lowest: compound 2; then compound 3; then compounds 1 and 4 (each within the scatter of the next).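

In this assay there is a 1.3-fold higher number from compound 1 to compound 4 (0.12 log units; within the scatter) on the exchange of (4-methylpiperazin-1-yl)methyl for 4-propylpiperazin-1-yl on a saturated chain carbon, four bonds along the chain from an aromatic nitrogen. For the compounds shown here, this is the first measured step at this position, and it shows that one of these groups can stand in for the other there without a shift beyond the scatter in this read-out. Going by these compounds alone, the only information at hand concerns the drawn configuration of two other compounds and does not bear on this result.

The exchange alters the chain and the group on the piperazine together, so the compounds shown do not tell the contribution of either alone. Also open, from the compounds shown here alone, is how other groups at this place would read, such as a morpholine, a primary amine or a carboxylic acid.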